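The source may report more compounds than this note shows. Statements on the series, on what has been measured and on what is new or still open speak of the compounds shown alone.

The measured compounds, in a functional assay on PC-3 cells (Homo sapiens) for inhibition, read by sulforhodamine B assay, with a stated time of 72 h; on this read-out higher numbers stand for weaker inhibition and lower numbers for stronger inhibition:

Compound 1 `Nc1sc(-c2ccc(Cl)cc2)c(-c2ccc(Cl)cc2)c1C(=O)N1CCCC1` gives 6220 nM.
Compound 2 `Nc1sc(-c2ccc(Cl)cc2)c(-c2ccc(Cl)cc2)c1C(=O)N1CCNCC1` gives 2710 nM.
Compound 3 `Nc1sc(-c2ccc(Cl)cc2)c(-c2ccc(Cl)cc2)c1C(=O)NCc1ccccc1` gives 31800 nM.

Compound 3 stands highest of the three numbers: the step of a 5.1-fold higher number from compound 1 to compound 3 (0.71 log units; beyond the scatter) is modest, and the step of a 12-fold higher number from compound 2 to compound 3 (1.07 log units; beyond the scatter) is large. Compound 4 `CN1CCN(C(=O)c2c(N)sc(-c3ccc(Cl)cc3)c2-c2ccc(Cl)cc2)CC1` differs from compound 3 in one place: 4-methylpiperazin-1-yl in place of benzylamino on a carbonyl carbon. The step that bears most directly on this is a 12-fold higher number from compound 2 to compound 3 (1.07 log units; beyond the scatter), in which piperazin-1-yl and benzylamino were compared on the same carbonyl carbon; the step of a 5.1-fold higher number from compound 1 to compound 3 (0.71 log units; beyond the scatter) points the same way. Running that comparison in reverse, a large drop in this assay is expected, to a number near that of compound 2. Compound 4 is therefore estimated at 3000 nM, within 1200 nM to 8000 nM, an expected step of an 11-fold lower number from compound 3 to compound 4 (1.03 log units; beyond the scatter).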

Compound 4, half-maximal inhibitory concentration: 13100 nM
Estimate against measurement, compound 4: 4.4-fold (0.64 log units) below; measured number above the stated range.
By their numbers in this assay, from the lowest: compound 2; then compound 1; then compound 4; then compound 3.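

In this assay, methyl in place of hydrogen on the amine nitrogen in the ring is not a neutral change: it gives a 4.8-fold higher number from compound 2 to compound 4 (0.68 log units; beyond the scatter) and so the advantage of piperazin-1-yl does not carry over to its methylated form. The 4-methylpiperazin-1-yl group still gives a 2.4-fold lower number from compound 3 to compound 4 (0.39 log units; beyond the scatter) against benzylamino, yet it shows a 2.1-fold higher number from compound 1 to compound 4 (0.32 log units; beyond the scatter) against pyrrolidin-1-yl, which places piperazin-1-yl and its methylated form on opposite sides of pyrrolidin-1-yl. Nothing available explains this shift. The compounds shown leave open whether a longer chain such as ethyl, or an acetyl group, on that ring nitrogen would raise the number further.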